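Swapping Cyclohexylamino for Piperidin-1-yl on a Carbonyl Carbon

This account rests on a few compounds, and the source may have more. Where it says the series, first, only, none or still open, it means among the compounds named here.

In a functional assay on MIA PaCa-2 cells (Homo sapiens) for cytotoxicity, read by fluorescence, with a stated time of 48 h (on this read-out higher numbers stand for an effect only at larger amounts of compound and lower numbers for an effect already at smaller amounts), compound 1 `CC(C)=CCC/C(C)=C/CC/C(C)=C/CSC[C@H](NC(=O)CCCCCN1CCN(C)CC1)C(=O)NC1CCCCCC1` gives 2700 nM, the lowest number of the three measured. Compound 2 `CC(C)=CCC/C(C)=C/CC/C(C)=C/CSC[C@H](NC(=O)CCCCCN1CCCC1)C(=O)NC1CCCCC1` gives 5600 nM. Compound 3 `CC(C)=CCC/C(C)=C/CC/C(C)=C/CSC[C@H](NC(=O)CCCCCN1CCN(C)CC1)C(=O)N1CCCC1` gives 6000 nM, which lies within the scatter of the value for compound 2, so these two stand level, and both sit clearly higher than compound 1.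

Compound 4 `CC(C)=CCC/C(C)=C/CC/C(C)=C/CSC[C@H](NC(=O)CCCCCN1CCCC1)C(=O)N1CCCCC1` has not yet been measured. It carries piperidin-1-yl in place of cyclohexylamino on a carbonyl carbon.

Among the compounds with values here, only one measured step bears on this change: a 2.2-fold higher number from compound 1 to compound 3 (0.35 log units; beyond the scatter). There, pyrrolidin-1-yl replaced cycloheptylamino at a carbonyl carbon. The guide is imperfect, since that pair also differs from compound 2 elsewhere and the groups are not the same ones. A modest step towards a higher number is therefore expected in this assay, in the same direction but held somewhat smaller. The expected change is a 1.7-fold higher number from compound 2 to compound 4 (0.23 log units; within the scatter). For compound 4 the estimate is 9500 nM, with an expected range from 4500 nM to 20000 nM.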

Compound 4, half-maximal effective concentration: 12400 nM
Beside the measured number, compound 4's estimate is 1.3-fold (0.12 log units) below it, and the stated range covers the measured number.
By their numbers in this assay, from the lowest: compound 1; then compounds 2 and 3 (each within the scatter of the next); then compound 4.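

In this assay, the change from cyclohexylamino to piperidin-1-yl on the carbonyl carbon gives a 2.2-fold higher number from compound 2 to compound 4 (0.35 log units; beyond the scatter). This shows that a higher number on replacing a ring-bearing amino group at this carbonyl carbon also appears in a second background, and without the change of ring size seen in the earlier step: the ring stays six-membered, while the entering group has no hydrogen-bond donor and the leaving group has one. No measurement shown accounts for this rise.

The compounds shown leave open whether the rise goes with the loss of the amide hydrogen or with the ring nitrogen being part of the ring itself. A methyl(cyclohexyl)amino group on the same carbonyl carbon, which keeps the all-carbon ring and carries no such hydrogen, would separate the two.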